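Halogen swap on the aryloxy arm of the shared core

The source may hold more compounds than are shown below. What is called first, only, known or untested is meant among the compounds shown, and "the series" means these compounds.

Going by the values given here, compound 1 `COc1cccc(CNCCCNc2ccnc3cc(Oc4ccc(Cl)cc4)ccc23)c1O` stands in an ADME assay on HepG2 cells (Homo sapiens) for cytotoxicity, read by luminescence, CellTiter-Glo and ATP content, with a stated time of 72 h (a lower number here means that less compound is needed, a higher number that more compound is needed for the effect), at 5700 nM, the second highest of the three numbers so far. Compound 3 `COc1cccc(Oc2ccc3c(NCCCNCc4cc(F)ccc4OC)ccnc3c2)c1` gives 7100 nM, within the scatter of compound 1, while compound 2 `COc1ccc(F)cc1CNCCCNc1ccnc2cc(C3CCCCC3)ccc12` gives 2290 nM, a lower number beyond the scatter. Among the compounds with values here, the one step in the set with a single change, a 3.1-fold higher number from compound 2 to compound 3 (0.49 log units; beyond the scatter), concerns a 3-methoxyphenoxy group in place of cyclohexyl and so a different part of the core than the one altered here.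

Compound 4 `COc1cccc(CNCCCNc2ccnc3cc(Oc4ccc(F)cc4)ccc23)c1O` differs from compound 1 by fluoro in place of chloro on an aromatic carbon. Within the data shown here, no measured pair bears on this change; none of the three compounds differs from another by a halogen alone, so nothing in the set argues for a shift either way. A step of a 1.1-fold higher number from compound 1 to compound 4 (0.02 log units; within the scatter) is therefore expected for compound 4, within the scatter. Compound 4 is estimated at 6000 nM, in the range 3000 nM to 12000 nM.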

Compound 4, half-maximal effective concentration: 11000 nM
Compound 4: the middle estimate sits 1.8-fold (0.26 log units) below what was measured; the measured number falls inside the stated range.
By their numbers in this assay, from the lowest: compound 2; then compounds 1, 3 and 4 (each within the scatter of the next).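

In this assay the exchange on the aryloxy arm gives a 1.9-fold higher number from compound 1 to compound 4 (0.29 log units; within the scatter), so 4-chlorophenoxy and 4-fluorophenoxy cannot be told apart at this position. Going by these compounds alone, this is the first pair that differs by a halogen alone, and it adds a reading at a place on an aromatic carbon that the earlier step, with 3-methoxyphenoxy in place of cyclohexyl, did not touch. No supporting measurement bears on this result.

The compounds shown leave open whether a nitrile, a trifluoromethyl group or a carboxylic acid in place of the halogen on this ring would give a step beyond the scatter. They also leave open whether the same halogen exchange reads alike when the other end of the molecule differs, as it does in compound 3.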